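The source may report more compounds than this note shows. Statements on the series, on what has been measured and on what is new or still open speak of the compounds shown alone.

Values measured in a functional assay on HL-60 cells (Homo sapiens), with a stated time of 4 days (a lower number here means a stronger inhibitor, a higher number a weaker inhibitor), are as follows
- Compound 1 `O=C(NC1CCCCC1)c1nc[nH]c1C(=O)Nc1ccc(Cl)c(Cl)c1` gives 12300 nM
- Compound 2 `O=C(NCc1ccc(-c2ccccc2)cc1)c1nc[nH]c1C(=O)Nc1ccc(Cl)c(Cl)c1` gives 2900 nM
- Compound 3 `C[C@@H](NC(=O)c1[nH]cnc1C(=O)Nc1ccc(Cl)c(Cl)c1)c1ccccc1` gives 5900 nM

Compound 3 (5900 nM) sits in the middle of these three numbers. It is a weaker inhibitor than compound 2 and a stronger one than compound 1, with both gaps just beyond the usual scatter.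

Still unmeasured is compound 4 `COC(=O)[C@@H](NC(=O)c1[nH]cnc1C(=O)Nc1ccc(Cl)c(Cl)c1)C(C)C` which has 1-(methoxycarbonyl)-2-methylpropyl in place of 1-phenylethyl on an amide-type nitrogen. For the measured compounds named here, no two measured compounds differ in one place only, so there is no direct precedent for this change. The group on that nitrogen holds an aromatic ring in compound 2 (2900 nM) and in compound 3 (5900 nM) but not in compound 1 (12300 nM), which has the highest number. Compound 4 also has no ring there. This is a thin hint from three compounds, but it points to a modest weakening, so a higher number is expected, a 1.5-fold higher number from compound 3 to compound 4 (0.18 log units; within the scatter), perhaps not far beyond the scatter. The estimate for compound 4 is 9000 nM, with an expected range from 3500 nM to 25000 nM.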

Compound 4, half-maximal inhibitory concentration: > 62500 nM
Compound 4: no number, only a limit (the forecaster's own chance of this, stated with the estimate: 10%); middle value at least 6.9-fold (0.84 log units) from the limit.
By their numbers in this assay, from the lowest: compound 2; then compound 3; then compound 1. At a limit, above all of these: compound 4.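

In this assay, placing 1-(methoxycarbonyl)-2-methylpropyl instead of 1-phenylethyl on the amide-type nitrogen gives an at least 10-fold higher number from compound 3 to compound 4 (1.02 log units; beyond the scatter), a large loss of inhibition. Compound 4 gives > 62500 nM, which is a limit of the assay and not a number. The earlier compounds spanned only a modest range, whereas this position now proves highly sensitive to the group it carries, even though the two groups match in heavy-atom count, and the true size of the step stays unknown: the limit of > 62500 nM in this assay, at which 1 of the 4 values shown sits.

This single change removes the aromatic ring and adds the methyl ester together, so the compounds shown cannot separate the two effects. A group holding both a phenyl ring and a methyl ester, or a carboxylic acid in place of that ester, would be needed to tell them apart.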